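The source may report more compounds than this note shows. Statements on the series, on what has been measured and on what is new or still open speak of the compounds shown alone.

Working notes on the series. In an ADME assay on Vero cells (Chlorocebus sabaeus) for cytotoxicity, read by MTT assay, with a stated time of 72 h (a higher number here means a weaker inhibitor, a lower number a stronger inhibitor), compound 1 `O=C(O)c1cn(C2CC2)c2nc(N3CCC4(CC3)OCCO4)c([N+](=O)[O-])cc2c1=O` gives 150000 nM, compound 2 `O=C(O)c1cn2c(n1)CN(c1nc3c(cc1[N+](=O)[O-])c(=O)c(C(=O)O)cn3C1CC1)CC2` gives 142000 nM, and compound 3 `CC1(C)COCN1c1nc2c(cc1[N+](=O)[O-])c(=O)c(C(=O)O)cn2C1CC1` gives 167000 nM. Compound 1 therefore stands within the scatter of both neighbours, and the three numbers cannot be ordered.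

Compound 4 `O=C(O)c1cn(-c2ccc(F)cc2)c2nc(N3CCC4(CC3)OCCO4)c([N+](=O)[O-])cc2c1=O` keeps the rest of compound 1 and changes one group, with 4-fluorophenyl in place of cyclopropyl on an aromatic nitrogen.

For the measured compounds named here, the only measured step is a 1.1-fold higher number from compound 1 to compound 3 (0.05 log units; within the scatter). That change sits on an aromatic carbon, not on the aromatic nitrogen, and it stays within the scatter. Going by the values given here, all three measured compounds carry cyclopropyl on the aromatic nitrogen, so the data contain no direct precedent for this replacement. The step from compound 1 to compound 3 bears on it only indirectly, showing that this assay did not move when another part of the structure was changed.

No step beyond the scatter is therefore expected, with only a slight lean towards a lower number for the larger entering group. The expected step is a 1.3-fold lower number from compound 1 to compound 4 (0.10 log units; within the scatter). The estimated value for compound 4 is 120000 nM, with an expected range of 55000 nM to 220000 nM.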

Compound 4, half-maximal inhibitory concentration: 133000 nM
Beside the measured number, compound 4's estimate is 1.1-fold (0.04 log units) below it; low and high end bracket the measured number.
By their numbers in this assay, from the lowest: compounds 4, 2, 1 and 3 (each within the scatter of the next).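

In this assay, for the compounds shown here, 4-fluorophenyl in place of cyclopropyl on the aromatic nitrogen gives a 1.1-fold lower number from compound 1 to compound 4 (0.05 log units; within the scatter), the first reading at this position, since compounds 1, 2 and 3 all carry cyclopropyl there. A six-membered aromatic ring of carbon only can therefore replace a three-membered non-aromatic ring on this nitrogen with no step beyond the scatter, and the same holds for the change on the aromatic carbon, a 1.1-fold higher number from compound 1 to compound 3 (0.05 log units; within the scatter). No measurement on these compounds speaks to the reason for this result.

As far as these compounds go, the leaving and entering groups both have no hydrogen-bond donors, no hydrogen-bond acceptors and no net charge, so it remains open whether the number would hold with an amine, a carboxylic acid or a longer alkyl chain on this nitrogen. Also open, from the compounds shown here alone, is whether 4-fluorophenyl would give the same reading when paired with the group on the aromatic carbon of compound 2 or compound 3, rather than with that of compound 1.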